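The source may hold more compounds than are shown below. What is called first, only, known or untested is meant among the compounds shown, and "the series" means these compounds.

Compounds measured in a functional assay on SEM cells (Homo sapiens) for cytotoxicity, with a stated time of 72 h; a higher number here means that more compound is needed for the effect, a lower number that less compound is needed:

- Compound 1 `C=C[C@@](C)(/C=C/c1ccc(O)cc1)CCCO`: > 36600 nM
- Compound 2 `C=C[C@@](C)(/C=C/c1ccc(O)c(/C=C/C(=O)NCc2ccc(C(F)(F)F)cc2)c1)CCC=C(C)C`: > 36600 nM
- Compound 3 `CC(C)=CCC[C@@](C)(/C=C/c1ccccc1)/C=C/c1ccc(O)cc1`: > 36600 nM

Among the measured compounds shown here, none of these three readings is a number, and the series so far is summed up by the limit of > 36600 nM in this assay, at which 3 of the 3 values shown sit. Compound 3 gives > 36600 nM, which is a limit of the assay. For the measured compounds named here, the other two compounds also give only a limit, so the data place no order among the three and show no step between any of them.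

The next compound to be tested is compound 4 `CC(C)=CCC[C@](C)(/C=C/c1ccc(O)cc1)/C=C/c1ccc(C#N)cc1`. It keeps the structure of compound 3 except that phenyl becomes 4-cyanophenyl, with cyano in place of hydrogen on an aromatic carbon, para to a large group (cyano in place of hydrogen on an aromatic carbon). Going by the values given here, no measured pair shows what a single change does in this assay, so the only anchor is compound 3 with its limit of > 36600 nM. On that basis, no shift beyond the usual scatter is expected in either direction, and another limit is the likeliest reading. The estimated change, a number no higher from compound 3 to compound 4 (the limit leaves the size open), is expected to stay within the scatter. Compound 4 is expected to lie near 36600 nM, with an estimated range from 15000 nM to 60000 nM.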

Compound 4, half-maximal effective concentration: > 36600 nM
Compound 4: a limit, no number (the forecaster's own chance of this, stated with the estimate: 80%); the middle value lies on the limit itself.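

In this assay compound 4 gives > 36600 nM, which is a limit and not a number. Compound 3 also gives only a limit, so the step between compound 3 and compound 4 cannot be read. The compounds shown leave open what any single change does in this assay, and the series stays at one reading: the limit of > 36600 nM in this assay, at which 4 of the 4 values shown sit.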